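The compounds below may be only part of what the source reports. "The series", "measured", "known", "first", "only" and "open" are said of these compounds alone.

Three compounds share a core in which a chain ending in a carbonyl links two aromatic rings. Compound 1 `COc1cc(-c2cc(/C=C/C(=O)c3ccc(N)cc3)[nH]n2)cc(OC)c1OC` gives 1420 nM in a functional assay on T47D cells (Homo sapiens) for inhibition, read by sulforhodamine B assay, with a stated time of 48 h; on this read-out lower numbers stand for stronger inhibition of growth and higher numbers for weaker inhibition of growth; compound 2 `COc1ccc(-c2cc(/C=C/C(=O)c3ccc(OC)c(OC)c3)[nH]n2)cc1` gives 1600 nM, and compound 3 `COc1cc(-c2cc(/C=C/C(=O)c3ccc(Cl)c(Cl)c3)[nH]n2)cc(OC)c1OC` gives 1660 nM. Compound 1 has the lowest of the three numbers, but its gaps to compound 2 and to compound 3 are both within the scatter, so no ordering can be read. Within the data shown here, the single step between compounds differing in one place, a 1.2-fold higher number from compound 1 to compound 3 (0.07 log units; within the scatter), puts 3,4-dichlorophenyl in place of 4-aminophenyl on the carbonyl carbon and leaves the number essentially where it was.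

Compound 4 `COc1ccc(-c2cc(/C=C/C(=O)c3ccc(N)cc3)[nH]n2)cc1OC` is compound 1 with one change: hydrogen in place of methoxy on an aromatic carbon. Among the measured compounds shown here, no measured step touches this ring; the step from compound 1 to compound 3 concerns the other end of the molecule, and compound 2 differs from compound 1 in more than one place, so it offers no direct guide. With nothing to lean on, the expectation for compound 4 is a modest weakening, a 1.8-fold higher number from compound 1 to compound 4 (0.25 log units; within the scatter), held with a wide range. Compound 4 is therefore estimated at 2500 nM, between 1000 nM and 6000 nM.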

Compound 4, concentration for 50% growth inhibition: 4250 nM
Beside the measured number, compound 4's estimate is 1.7-fold (0.23 log units) below it; low and high end bracket the measured number.
By their numbers in this assay, from the lowest: compounds 1, 2 and 3 (each within the scatter of the next); then compound 4.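

Replacing one methoxy group with hydrogen gives a 3.0-fold higher number from compound 1 to compound 4 (0.48 log units; beyond the scatter) in this assay, meaning weaker inhibition of growth. Unlike a 1.2-fold higher number from compound 1 to compound 3 (0.07 log units; within the scatter), this change at the other end of the molecule moves the number beyond the scatter, so in this pair the methoxy group at this place on the ring, ortho to a methoxy group, makes a measurable difference. No measurement shown here explains this rise.

From the compounds shown here alone, how a hydroxyl group, a fluorine atom or an ethoxy group at the same place would compare with methoxy and hydrogen stays open. Also open, going by these compounds, is whether the same replacement would have a similar size with the 3,4-dichlorophenyl group of compound 3 on the carbonyl carbon.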